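Swapping an aryl amide for a lactam on the shared core

The source may hold more compounds than are shown below. What is called first, only, known or untested is meant among the compounds shown, and "the series" means these compounds.

Compound 3 `CNC(=O)c1ccc(-c2cnc(NCc3c(F)ccc4c3CCO4)c3cn[nH]c(=O)c23)c(C)n1` stands second highest of three in a physicochemical assay for lipophilicity, using the shake flask method, in phosphate buffer, measured as octanol-water partition, with a stated time of 30 min, at pH 7.4 (on this read-out higher numbers stand for higher lipophilicity and lower numbers for lower lipophilicity), where compound 3 gives 2.9. Compound 1 `Cc1cc(-c2cnc(NCc3c(F)ccc4c3CCO4)c3cn[nH]c(=O)c23)n(C)n1` gives 3, a value within the scatter of compound 3, while compound 2 `CNC(=O)c1cc(-c2cnc(NCc3c(F)ccc4c3CCO4)c3cn[nH]c(=O)c23)n(C)n1` gives 2.1. Compound 4 `O=C1CCCN1c1cnc(NCc2c(F)ccc3c2CCO3)c2cn[nH]c(=O)c12` carries the change (2-oxopyrrolidin-1-yl in place of 2-methyl-6-(methylcarbamoyl)pyridin-3-yl on an aromatic carbon). Among the compounds with values here, no measured step matches this change; the closest guides are a number 0.90 log units lower from compound 1 to compound 2 (beyond the scatter) and a number 0.80 log units higher from compound 2 to compound 3 (beyond the scatter), both modest and both tied to the methylcarbamoyl group that now leaves. Since the entering group is smaller and keeps one carbonyl, a modest drop beyond the scatter is expected, namely a number 1.00 log units lower from compound 3 to compound 4 (beyond the scatter). Compound 4 is therefore estimated at 1.9, with a range from 1.3 to 2.5.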

Compound 4, distribution coefficient: 1.8
Compound 4: the middle estimate sits 0.10 log units above what was measured; low and high end bracket the measured number.
By their numbers in this assay, from the lowest: compounds 4 and 2 (each within the scatter of the next); then compounds 3 and 1 (each within the scatter of the next).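

At this aromatic carbon of the shared core, compounds 1 to 3 carry only aromatic rings, and 2-oxopyrrolidin-1-yl shows what a small non-aromatic ring does in this assay: large steps from both neighbours without a methylcarbamoyl on a pyrazole (a number 1.10 log units lower from compound 3 to compound 4 (beyond the scatter); a number 1.20 log units lower from compound 1 to compound 4 (beyond the scatter)). Against 1-methyl-3-(methylcarbamoyl)-1H-pyrazol-5-yl, the same swap gives a much smaller step (a number 0.30 log units lower from compound 2 to compound 4 (within the scatter)). Nothing available explains these steps. From the compounds shown here alone, whether the ring or its carbonyl matters more stays open, and a plain pyrrolidine or a morpholine on this carbon would help separate the two.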